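The source may hold more compounds than are shown below. What is called first, only, known or untested is meant among the compounds shown, and "the series" means these compounds.

Measured in an ADME assay on HEL cells (Homo sapiens) for cytotoxicity, with a stated time of 3 days; a lower number here means that less compound is tolerated, a higher number that more compound is tolerated:
Compound 1 `CCC1(Cc2ccccc2)OS(=O)(=O)C=C1OCC(=O)OC` gives > 200000 nM, which is a limit of the assay and not a number.
Compound 2 `CCC1(Cc2ccccc2)OS(=O)(=O)C=C1OCc1ccccc1` gives 200000 nM.

Compound 2 thus holds the only number shown in this assay; the further value shown is a limit. For the measured compounds named here, the one measured step, a number no higher from compound 1 to compound 2 (the limit leaves the size open), has a size that cannot be read, since the limit of > 200000 nM in this assay, at which 1 of the 2 values shown sits, leaves its extent open. Compound 3 `CCC1(Cc2ccccc2)OS(=O)(=O)C=C1OCc1ccc(OC)cc1` differs from compound 2 by methoxy in place of hydrogen on an aromatic carbon. Going by the values given here, no measured step bears on a change of this kind, and the single step on record gives no readable size, so in this assay no step beyond the scatter is expected from compound 2 to compound 3. Compound 3 is therefore expected to give about 200000 nM, within a range from 100000 nM to 400000 nM, with a fair chance that only a limit is reported. The step this estimate means is no change at the digits printed from compound 2 to compound 3 (within the scatter).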

Compound 3, half-maximal cytotoxic concentration: > 200000 nM
Compound 3: no number, only a limit (the forecaster's own chance of this, stated with the estimate: 50%); the middle value lies on the limit itself.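

In this assay compound 3 gives > 200000 nM, which is a limit of the assay and not a number. Methoxy in place of hydrogen on an aromatic carbon, para to a large group, is the first change on this ring on record, and it gives no sign that less compound is tolerated than with compound 2. The steps to compound 3 from compound 2 and from compound 1 cannot be read because the values gather at one end of the scale: the limit of > 200000 nM in this assay, at which 2 of the 3 values shown sit.

In this assay the record for this change is a number no lower from compound 2 to compound 3 (the limit leaves the size open) and nothing more. Going by these compounds, with compound 2 alone holding a number, the size of any effect of a change at this position remains unknown.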